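A few compounds are considered here, and "the series" means these few. Any claim that something is new, unique, unknown or untested is made for them only; others in the source may bear on it.

Measured so far:

Compound 1 `C=C1CC[C@H]2C(C)(C)CCC[C@]2(C)[C@H]1CC(O)c1ccoc1` gives 3.9 ug/mL in a functional assay on SNU1 cells (Homo sapiens) for cytotoxicity; on this read-out lower numbers stand for stronger inhibition and higher numbers for weaker inhibition.
Compound 2 `C=C1[C@H](O)C[C@H]2C(C)(C)CCC[C@]2(C)[C@H]1/C=C/c1ccoc1` gives 4.8 ug/mL in this assay.

Compound 1 has the lower of the two numbers, but compound 2 sits close to it, and the gap between them lies within the usual scatter of repeated measurements; the two results are best read as the same.

Compound 3 `C=C1CC[C@H]2C(C)(C)CCC[C@]2(C)[C@H]1C/C=C(\CO)CCO` has not yet been measured. Compared with compound 1, the change is 4-hydroxy-2-(hydroxymethyl)but-1-en-1-yl in place of (furan-3-yl)(hydroxy)methyl on a saturated chain carbon bound to a saturated ring carbon. The ring is lost, and an open chain carrying 1 double bond outside aromatic rings and 2 hydrogen-bond donors takes its place. Within the data shown here, no measured pair shows what such a change does here, so the expected direction rests only on the two numbers at hand. The estimate for compound 3 is a weakening, a step of a 2.1-fold higher number from compound 1 to compound 3 (0.31 log units; beyond the scatter), giving an expected value of 8 ug/mL with a likely range from 3 ug/mL to 25 ug/mL.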

Compound 3, half-maximal inhibitory concentration: 8.6 ug/mL
The estimate for compound 3 lay 1.1-fold (0.03 log units) below the measured number; measured number inside the range.
By their numbers in this assay, from the lowest: compounds 1, 2 and 3 (each within the scatter of the next, the first and the last beyond it).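

In this assay, among these compounds, putting 4-hydroxy-2-(hydroxymethyl)but-1-en-1-yl in place of (furan-3-yl)(hydroxy)methyl gives a 2.2-fold higher number from compound 1 to compound 3 (0.34 log units; beyond the scatter), the first step that can be read at this place on a saturated chain carbon bound to a saturated ring carbon. The step is modest, so the core of compound 1 still gives a measurable value with no five-membered aromatic ring at this place, and the open chain, with its double bond and extra hydrogen-bond donor, gives up only a little. Nothing available explains why the number rises.

Going by these compounds, this single swap removes the ring and adds the chain features together, so the share of each remains open. Also open, on these data alone, is how an amine, a carboxylic acid or a longer chain would read at the same place.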